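The source may report more compounds than this note shows. Statements on the series, on what has been measured and on what is new or still open speak of the compounds shown alone.

Within the data shown here, compound 1, `N=S1(=O)c2ccccc2C(=O)N1c1ccccc1`, is the one compound of the pair with a number in hand: in a physicochemical assay for acid dissociation, read by spectrophotometry, compound 1 gives 8.3. Compound 2, `CCN1C(=O)c2ccccc2S1(=O)=O`, has in this assay only the entry "not determined" (no result reported), so it offers no second point. Compound 3, `CCN1C(=O)c2ccccc2S1(=N)=O`, is not yet measured. The change from compound 1 to compound 3 is ethyl in place of phenyl on an amide-type nitrogen in a ring. Among the measured compounds shown here, with no measured step to lean on, the shift from compound 1 to compound 3 in this assay is expected to be small and upward, about a number 0.40 log units higher from compound 1 to compound 3 (beyond the scatter). Compound 3 is therefore estimated at 8.7, with a range from 8.1 to 9.3.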

Compound 3, acid dissociation constant: 8.9
Estimate against measurement, compound 3: 0.20 log units below; the measured number falls inside the stated range.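

In this assay, among these compounds, ethyl in place of phenyl on an amide-type nitrogen in a ring gives the first measured step at this place: a number 0.60 log units higher from compound 1 to compound 3 (beyond the scatter) with nothing else in the shared core changed. This shows that the read-out responds to the group on this nitrogen, although the finding rests on a single pair. No available evidence accounts for the direction or size of this step. From the compounds shown here alone, whether a longer chain or a benzyl group on this nitrogen would continue the shift remains open. Also open, going by these compounds, is whether the step would hold in a different core.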